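A Carboxyphenyl Swapped for a Phenylpropyl Chain

This account rests on a few compounds, and the source may have more. Where it says the series, first, only, none or still open, it means among the compounds named here.

In a functional assay (plasma) for inhibition, with Oryctolagus cuniculus as the target (on this read-out lower numbers stand for stronger inhibition and higher numbers for weaker inhibition), compound 1 `CCCCCc1ccc(S(=O)(=O)N[C@H]2C3CC[C@H](C3)[C@@H]2C/C=C\CCCC(=O)O)cc1` gives 800000 nM and compound 2 `O=C(O)CCC/C=C\C[C@H]1[C@@H]2CCC(C2)[C@@H]1NS(=O)(=O)c1ccc(C(=O)O)cc1` gives 800000 nM, so compound 2 stands level with compound 1. For compound 3 `O=C(O)CCC/C=C\C[C@H]1[C@@H]2CCC(C2)[C@@H]1NC(=O)c1ccccc1`, this assay reports only a limit, > 800000 nM. That makes (the limit of > 800000 nM in this assay, at which 1 of the 3 values shown sits), so the measurements sit close to the edge of what the test can report.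

Compound 4 `O=C(O)CCC/C=C\C[C@H]1[C@@H]2CCC(C2)[C@@H]1NS(=O)(=O)CCCc1ccccc1` brings 3-phenylpropyl in place of 4-carboxyphenyl on a sulfonyl sulfur. Going by the values given here, only one measured step bears on this change. Putting carboxy in place of pentyl on an aromatic carbon gave no change at the digits printed from compound 1 to compound 2 (within the scatter). That step changed a different group, so it is a weak guide, but it offers no reason to expect a large move. The expected result is a 1.6-fold lower number from compound 2 to compound 4 (0.20 log units; within the scatter), which would not go beyond the scatter. Among the compounds with values here, no measured step involves 3-phenylpropyl, so the range is wide and leans toward stronger inhibition. For compound 4 the estimate is 500000 nM, with an expected range of 60000 nM to 800000 nM.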

Compound 4, half-maximal inhibitory concentration: 14000 nM
Estimate against measurement, compound 4: 36-fold (1.55 log units) above; the whole stated range lies above it.
By their numbers in this assay, from the lowest: compound 4; then compounds 1 and 2 (each within the scatter of the next).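

The sulfonyl sulfur turns out to be a place where the choice of group matters in this assay, with a 57-fold lower number from compound 2 to compound 4 (1.76 log units; beyond the scatter), the first step shown that lies beyond the scatter. The swap keeps the same number of heavy atoms and one aromatic ring, yet it loses the hydrogen-bond donor and acceptor of 4-carboxyphenyl and carries the ring on a propyl chain. Going by these compounds alone, compound 4 is also the one value shown that lies well away from the edge of what the test can report: the limit of > 800000 nM in this assay, at which 1 of the 4 values shown sits.

Losing the carboxy group and gaining the propyl chain happen together in this single step, so their separate shares remain unknown. A benzyl or 2-phenylethyl group on the sulfonyl sulfur, or an amine at the end of the chain, remains an open case.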